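Chloro on the phenyl ring: one step, two positions

A few compounds are considered here, and "the series" means these few. Any claim that something is new, unique, unknown or untested is made for them only; others in the source may bear on it.

Compound 1, `CCCCCCCCc1ccc(OCC(=O)Cn2nnnc2-c2ccccc2)cc1`, is kept to 36% in an ADME assay on S9 fraction from liver (Rattus norvegicus) for metabolic stability, read by LC-MS, using NADPH, with a stated time of 30 min; a higher number here means that more of the compound is left, a lower number that less of the compound is left. Compound 2, `CCCCCCCCc1ccc(OCC(=O)Cn2nnnc2-c2ccccc2Cl)cc1`, differs only in the change chloro in place of hydrogen on an aromatic carbon and gives 42% in this assay, so a number 6 percentage points higher from compound 1 to compound 2 (within the scatter). Compound 3, `CCCCCCCCc1ccc(OC(C)C(=O)Cn2nnc(-c3ccccc3)n2)cc1`, has a different core; the difference between the two cores is not broken down here. In this assay compound 3 gives 40%. Compound 4, `CCCCCCCCc1ccc(OC(C)C(=O)Cn2nnc(-c3ccc(Cl)cc3)n2)cc1`, carries the change (chloro in place of hydrogen on an aromatic carbon). Among the measured compounds shown here, this is the same kind of change as the one from compound 1 to compound 2, not the same: there the chloro sits ortho to a large group, here para to a large group. The step is expected to be about a number 4 percentage points higher from compound 3 to compound 4 (within the scatter), because a number 6 percentage points higher from compound 1 to compound 2 (within the scatter). Compound 4 is therefore estimated at about 44%, likely between 30% and 58%.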

Compound 4, percent of the compound remaining: 72%
Beside the measured number, compound 4's estimate is 28 percentage points below it; measured number above the stated range.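

The chloro step in this assay gives a number 32 percentage points higher from compound 3 to compound 4 (beyond the scatter). The same kind of change therefore did not carry over in size from one core to the other: the same change on two cores in this assay, a number 6 percentage points higher (within the scatter) from compound 1 to compound 2 and a number 32 percentage points higher (beyond the scatter) from compound 3 to compound 4, 26 percentage points apart, beyond the scatter of two such steps. The two steps differ both in the core and in where the chloro sits on the phenyl ring, so these numbers cannot say which of the two sets the gap.

Still open, from the compounds shown here alone, is what a chloro para to a large group would do on the core of compound 1, which would separate the two explanations. Also open, going by these compounds, is whether a fluoro or a methyl in that same place would behave as the chloro does on the core of compound 3.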